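Bromo to Trifluoromethyl on the Distal Aromatic Ring

The source may report more compounds than this note shows. Statements on the series, on what has been measured and on what is new or still open speak of the compounds shown alone.

Measured compounds:
compound 1 `O=S(=O)(Nc1cccc(CO)c1)c1ccc(-c2ccccc2)cc1`: 2200 nM
compound 2 `O=S(=O)(Nc1cccc(CO)c1)c1ccc(-c2ccc(Br)cc2)cc1`: 2500 nM

Of the compounds shown here, two have been measured in a functional assay on J774 cells (Mus musculus) for cytotoxicity, read by resazurin assay, with a stated time of 72 h; on this read-out higher numbers stand for weaker inhibition and lower numbers for stronger inhibition. Compound 2 gives 2500 nM and stands highest of the two numbers, with compound 1 nearest; the step of a 1.1-fold higher number from compound 1 to compound 2 (0.06 log units; within the scatter) lies within the scatter, so the two compounds cannot be ordered on this read-out.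

Compound 3 `O=S(=O)(Nc1cccc(CO)c1)c1ccc(-c2ccc(C(F)(F)F)cc2)cc1` differs from compound 2 by trifluoromethyl in place of bromo on an aromatic carbon. Among the measured compounds shown here, the only measured step that bears on this position is the one from compound 1 to compound 2, in which bromo entered in place of hydrogen at the same carbon and the number barely moved. For the measured compounds named here, no measured step exchanges bromo for trifluoromethyl, so the expectation rests on the single step at this position being small.

On that basis compound 3 is expected to give about 2500 nM in this assay, with a range from 1200 nM to 5500 nM. The step of no change at the digits printed from compound 2 to compound 3 (within the scatter) is estimated to remain within the scatter, in no clear direction.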

Compound 3, half-maximal inhibitory concentration: 2500 nM
Compound 3: the middle estimate sits on the measured number at the digits printed, within the range that was stated.
By their numbers in this assay, from the lowest: compounds 1, 2 and 3 (each within the scatter of the next).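

In this assay, trifluoromethyl in place of bromo on this aromatic carbon, para to a large group, gives no change at the digits printed from compound 2 to compound 3 (within the scatter), although the entering group holds more heavy atoms than the one it replaces. Read against the unsubstituted compound, trifluoromethyl in place of hydrogen gives a 1.1-fold higher number from compound 1 to compound 3 (0.06 log units; within the scatter), so this carbon now has two different substituents, bromo and trifluoromethyl, and neither separates from hydrogen on this read-out, where before there was only one. The three compounds therefore cannot be ordered, and no available evidence bears on why the number stays so flat at this position.

What the compounds shown leave open is whether this flatness extends beyond these groups: an amine or a carboxylic acid on the same carbon, or a longer chain such as a butyl group, might still move the number beyond the scatter. They also leave open whether the same carbon stays this flat when the hydroxymethyl group elsewhere on the core of compound 1 is replaced, since all three compounds carry it unchanged.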